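Taking one methyl off compound 1

The source may report more compounds than this note shows. Statements on the series, on what has been measured and on what is new or still open speak of the compounds shown alone.

In a functional assay on RL cells (Homo sapiens) for cytotoxicity, with a stated time of 48 h (on this read-out higher numbers stand for weaker inhibition and lower numbers for stronger inhibition), compound 1 `COc1cc(OC)c(C(=O)/C=C/c2ccccc2OC)c(OC)c1` gives 9000 nM and compound 2 `COc1cc(OC)c(C(=O)/C=C/c2ccccc2SC)c(OC)c1` gives 8300 nM, so the two stand level within the scatter. Compound 3 `COc1cc(O)c(C(=O)/C=C/c2ccccc2OC)c(OC)c1` differs from compound 1 in one place: hydrogen in place of methyl on an oxygen on an aromatic ring, which turns methoxy to hydroxy. Among the measured compounds shown here, the only measured step, a 1.1-fold lower number from compound 1 to compound 2 (0.04 log units; within the scatter), replaced a different methoxy group and stayed within the scatter, so it offers only weak guidance. No step beyond the scatter is therefore expected, and the estimated move is a 1.3-fold lower number from compound 1 to compound 3 (0.11 log units; within the scatter). For compound 3 the estimated value is 7000 nM, with an expected range of 2500 nM to 20000 nM.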

Compound 3, half-maximal inhibitory concentration: 10100 nM
Estimate against measurement, compound 3: 1.4-fold (0.16 log units) below; measured number inside the range.
By their numbers in this assay, from the lowest: compounds 2, 1 and 3 (each within the scatter of the next).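

In this assay, putting hydrogen in place of methyl on an oxygen on an aromatic ring gives a 1.1-fold higher number from compound 1 to compound 3 (0.05 log units; within the scatter) and so leaves the read-out level within the scatter. Among the compounds shown here, compound 2 changed a different methoxy group, so this is the first sign that this methyl, too, can go without a step beyond the scatter. No supporting data bear on why the change does so little. The compounds shown leave open whether an amine or a longer chain, such as ethoxy, on this carbon or oxygen would also stay level. A single pair also cannot show whether the same swap would behave alike on the other methoxy groups.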